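Adding a Fluorine to a Fused-Ring Inhibitor Series

A few compounds are considered here, and "the series" means these few. Any claim that something is new, unique, unknown or untested is made for them only; others in the source may bear on it.

Compound 1 `CC(c1cc2cccnc2cc1F)n1cnc2ncc(-c3cnn(CCO)c3)nc21` and compound 2 `CC(c1c(F)cc2ncccc2c1F)n1cnc2ncc(-c3cnn(CCO)c3)nc21` share one core and differ only by fluoro in place of hydrogen on an aromatic carbon. In a functional assay on NCI-H1993 cells (Homo sapiens) for inhibition, read by CCK-8 assay, with a stated time of 72 h (a lower number here means a stronger inhibitor, a higher number a weaker inhibitor), compound 1 gives 175 nM, while compound 2 gives 83.7 nM, so that a 2.1-fold lower number from compound 1 to compound 2 (0.32 log units; beyond the scatter). Compound 3 `COC(=O)c1ccc(-c2cnc3ncn(C(C)c4cc5cccnc5cc4F)c3n2)cc1F` carries a second core, differing from compound 1 by 3-fluoro-4-(methoxycarbonyl)phenyl in place of 1-(2-hydroxyethyl)-1H-pyrazol-4-yl on an aromatic carbon; in this assay compound 3 gives 60.2 nM, which means a 2.9-fold lower number from compound 1 to compound 3 (0.46 log units; beyond the scatter). Compound 4 `COC(=O)c1ccc(-c2cnc3ncn(C(C)c4c(F)cc5ncccc5c4F)c3n2)cc1F` has not yet been measured. It differs from compound 3 by fluoro in place of hydrogen on an aromatic carbon, the same change that turns compound 1 into compound 2, at a place described in identical words. A similar step is expected here, namely a 2.0-fold lower number from compound 3 to compound 4 (0.30 log units; within the scatter), because the same change once gave a 2.1-fold lower number from compound 1 to compound 2 (0.32 log units; beyond the scatter). Compound 4 is therefore estimated at 30 nM, most likely between 13 nM and 65 nM.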

Compound 4, half-maximal inhibitory concentration: 29.4 nM
For compound 4 the middle estimate is 1.0-fold (0.01 log units) above the measured one, and the stated range covers the measured number.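

In this assay the added fluoro gave a 2.0-fold lower number from compound 3 to compound 4 (0.31 log units; beyond the scatter), a step that carried over from the first core to the second: the same change on two cores in this assay, a 2.1-fold lower number (0.32 log units; beyond the scatter) from compound 1 to compound 2 and a 2.0-fold lower number (0.31 log units; beyond the scatter) from compound 3 to compound 4, 1.0-fold (0.01 log units) apart, within the scatter of two such steps. Placing 3-fluoro-4-(methoxycarbonyl)phenyl in place of 1-(2-hydroxyethyl)-1H-pyrazol-4-yl on the difluorinated compounds gave a 2.8-fold lower number from compound 2 to compound 4 (0.45 log units; beyond the scatter), and this change carried over as well: the same change on two cores in this assay, a 2.9-fold lower number (0.46 log units; beyond the scatter) from compound 1 to compound 3 and a 2.8-fold lower number (0.45 log units; beyond the scatter) from compound 2 to compound 4, 1.0-fold (0.01 log units) apart, within the scatter of two such steps. Both comparisons rest on the same four compounds, so they show that the two changes combined predictably here, not that the fluoro step would hold on other cores or why it lowers the number.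

Going by these compounds, it remains open whether chloro or methoxy at the same place would give a similar step. On these data alone, it is also open whether a carboxylic acid or an amide in place of the methyl ester would keep the pattern.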